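Piperazine bis-thiocarbonyl series: cytotoxicity notes toward compound 3

The compounds below may be only part of what the source reports. "The series", "measured", "known", "first", "only" and "open" are said of these compounds alone.

The series rests on a shared core carrying a dimethylthiocarbamoyl dithio group; compound 1 `CN1CCN(C(=S)SC(=S)N(C)C)CC1` bears a methyl on the amine nitrogen in the ring, and compound 2 `CCSC(=S)N1CCN(C(=S)SC(=S)N(C)C)CC1` carries an ethylsulfanyl thiocarbonyl group there instead. In an ADME assay on HeLa cells (Homo sapiens) for cytotoxicity, read by MTT assay, with a stated time of 24 h (a lower number here means a stronger inhibitor, a higher number a weaker inhibitor), compound 1 gives 1220000 nM, and compound 2 gives 4480000 nM. Within the data shown here, the one measured step, a 3.7-fold higher number from compound 1 to compound 2 (0.56 log units; beyond the scatter), is modest but beyond the scatter, so compound 2 stands with the highest number of the two measured compounds.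

Compound 3 `CCCCNC(=S)N1CCN(C(=S)SC(=S)N(C)C)CC1` differs from compound 2 in one place: butylamino in place of ethylsulfanyl on a thiocarbonyl carbon. Among the measured compounds shown here, no measured step touches this thiocarbonyl carbon; the single step in hand, a 3.7-fold higher number from compound 1 to compound 2 (0.56 log units; beyond the scatter), concerns the amine nitrogen in the ring and only shows that changes at the periphery of this core moved the read-out modestly. On that basis the step is expected to be small, with no direction that can be supported, and likely within the scatter. Compound 3 is expected to give about 4000000 nM, with a range from 1500000 nM to 12000000 nM. The expected step from compound 2 is a 1.1-fold lower number from compound 2 to compound 3 (0.05 log units; within the scatter).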

Compound 3, half-maximal inhibitory concentration: 2840000 nM
For compound 3 the middle estimate is 1.4-fold (0.15 log units) above the measured one; the range from low to high includes it.
By their numbers in this assay, from the lowest: compound 1; then compounds 3 and 2 (each within the scatter of the next).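

In this assay the thiocarbonyl carbon now has its first reading: butylamino in place of ethylsulfanyl gives a 1.6-fold lower number from compound 2 to compound 3 (0.20 log units; within the scatter) and so stays within the scatter, which means that the exchange of a sulfur-linked group for a nitrogen-linked group carrying a hydrogen-bond donor, with a longer chain, leaves compound 2 and compound 3 not separable in this read-out. Against the methyl of compound 1, the larger group on the amine nitrogen in a ring gives a 2.3-fold higher number from compound 1 to compound 3 (0.37 log units; beyond the scatter) as a modest step beyond the scatter, so the separation from compound 1 seen with compound 2 also holds for a second, different thiocarbonyl group. No measurement in hand explains either step.

Still open, as far as these compounds go, is whether an ethoxy group, a dimethylamino group, a carboxylic acid or a much longer chain on this thiocarbonyl carbon would move the number beyond the scatter. With a single amine at this carbon, the contribution of the nitrogen cannot be told apart from that of the butyl chain.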